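The source may report more compounds than this note shows. Statements on the series, on what has been measured and on what is new or still open speak of the compounds shown alone.

Compound 2 `Nc1ncnn2c([C@@H]3O[C@H](CO)[C@@H](O)[C@H]3O)cc(C#Cc3ccccc3)c12` is one of three analogues built on a shared core that differ only in the group on an aromatic carbon of the fused ring. In a functional assay on NCI-H460 cells (Homo sapiens) for antiproliferative activity, with a stated time of 72 h (on this read-out lower numbers stand for stronger inhibition and higher numbers for weaker inhibition), compound 2 gives 38500 nM, the lowest of the two numbers reported. Compound 1 `Nc1ncnn2c([C@@H]3O[C@H](CO)[C@@H](O)[C@H]3O)cc(C#Cc3ccc(F)cc3)c12` gives 79400 nM in this assay, and the step of a 2.1-fold lower number from compound 1 to compound 2 (0.31 log units; beyond the scatter) is modest. Compound 3 `Nc1ncnn2c([C@@H]3O[C@H](CO)[C@@H](O)[C@H]3O)cc(-c3ccccc3F)c12` reaches only a limit of this assay, > 100000 nM. The step of an at least 2.5-fold higher number from compound 2 to compound 3 (0.41 log units; beyond the scatter) accordingly points upward, as does an at least 1.2-fold higher number from compound 1 to compound 3 (0.10 log units; that floor lies within the scatter), although that floor lies within the scatter; both rest on the limit (the limit of > 100000 nM in this assay, at which 1 of the 3 values shown sits).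

Compound 4 `Nc1ncnn2c([C@@H]3O[C@H](CO)[C@@H](O)[C@H]3O)cc(-c3ccsc3)c12` is the unmeasured member. Compared with compound 2 it carries thiophen-3-yl in place of 2-phenylethynyl on an aromatic carbon. The nearest measured precedent is the step from compound 2 to compound 3, in which the 2-phenylethynyl group, with its one triple bond outside aromatic rings, gave way to an aromatic ring lacking any such bond and the number rose to the limit; compound 4 likewise gives up the 2-phenylethynyl group for a ring without a triple bond, here thiophen-3-yl. Compound 4 is therefore expected to show a higher number in this assay, estimated as the step of a 3.9-fold higher number from compound 2 to compound 4 (0.59 log units; beyond the scatter). Compound 4 is estimated at 150000 nM in this assay, between 50000 nM and 450000 nM, with a real chance that only a limit is reported.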

Compound 4, half-maximal inhibitory concentration: 35600 nM
Compound 4: middle estimate off by 4.2-fold (0.62 log units), on the high side; the whole stated range lies above it.
By their numbers in this assay, from the lowest: compounds 4 and 2 (each within the scatter of the next); then compound 1. At a limit, above all of these: compound 3.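

The result shows that, at this aromatic carbon of the five-membered ring, giving up the triple bond outside aromatic rings need not change the read-out in this assay: with thiophen-3-yl in place of 2-phenylethynyl there is a 1.1-fold lower number from compound 2 to compound 4 (0.03 log units; within the scatter). The same thiophen-3-yl group also compares favourably with the fluorinated alkyne, with a 2.2-fold lower number from compound 1 to compound 4 (0.35 log units; beyond the scatter), so a ring set directly on this carbon can match the better of the two alkynes and exceed the other. Directly attached rings also differ among themselves, with an at least 2.8-fold lower number from compound 3 to compound 4 (0.44 log units; beyond the scatter), so the loss of the triple bond alone does not account for the rise seen with 2-fluorophenyl, and this step rests on a limit: the limit of > 100000 nM in this assay, at which 1 of the 4 values shown sits.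

A plain phenyl group on this carbon would help to show whether the difference between compound 3 and compound 4 follows the fluoro group or the change of ring. From the compounds shown here alone, how far the position tolerates other groups also remains open, such as a furan-3-yl ring, a pyridin-3-yl ring, an amine or a short alkyl chain.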